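Methoxy in place of methylsulfanyl on compound 3

The compounds below may be only part of what the source reports. "The series", "measured", "known", "first", "only" and "open" are said of these compounds alone.

In an ADME assay on the whole organism (Rattus norvegicus) for pharmacokinetics, read by HPLC, at a dose of 3 mg/kg by the oral route (a lower number here means less compound in the circulation, a higher number more compound in the circulation at the dose given), compound 1 `C#Cc1cc(C(=O)N2CS(=O)(=O)c3ccccc32)cc(C#N)c1O` gives 4670 nM, compound 2 `CSc1cc(C(=O)N2CS(=O)(=O)c3ccccc32)cc(C#N)c1O` gives 3000 nM and compound 3 `CSc1cc(C(=O)N2CS(=O)(=O)c3ccccc32)cc(Cl)c1O` gives 12500 nM, the highest of the three numbers and beyond the scatter of both others. Compound 4 `COc1cc(C(=O)N2CS(=O)(=O)c3ccccc32)cc(Cl)c1O` carries methoxy in place of methylsulfanyl on an aromatic carbon, ortho to a hydroxy group (methoxy in place of methylsulfanyl on an aromatic carbon). Going by the values given here, no measured step exchanges these two groups. The step that brought in methylsulfanyl was a 1.6-fold lower number from compound 1 to compound 2 (0.19 log units; within the scatter), within the scatter. The step to chloro was a 4.2-fold higher number from compound 2 to compound 3 (0.62 log units; beyond the scatter), beyond the scatter, and compound 4 retains that chloro. The expected step is small, a 1.3-fold lower number from compound 3 to compound 4 (0.10 log units; within the scatter), within the scatter and without a firm direction. In this assay the estimate for compound 4 is 10000 nM, with an expected range of 4000 nM to 22000 nM.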

Compound 4, maximal plasma concentration: 3000 nM
Estimate against measurement, compound 4: 3.3-fold (0.52 log units) above; the measured number lies below the stated range.
By their numbers in this assay, from the lowest: compounds 2, 4 and 1 (each within the scatter of the next); then compound 3.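

In this assay, the position ortho to a hydroxy group proves sensitive to the group it carries: a 4.2-fold lower number from compound 3 to compound 4 (0.62 log units; beyond the scatter), whereas a 1.6-fold lower number from compound 1 to compound 2 (0.19 log units; within the scatter) stayed within the scatter. Chloro alone therefore does not secure the higher number seen in compound 3, since compound 4 keeps chloro and still loses it. No available evidence accounts for this drop.

On these data alone, whether methoxy has the same effect with nitrile in place of chloro remains open. So does the outcome with ethoxy, a longer chain, or an amine at this position.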